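The source may report more compounds than this note shows. Statements on the series, on what has been measured and on what is new or still open speak of the compounds shown alone.

Measured compounds:
Compound 1, `CCCC1CCCCC1OCCCCCCN1C[C@H](O)[C@@H](O)[C@H](O)[C@H]1CO` — in an ADME assay on MDBK cells (Bos taurus) for cytotoxicity, read by MTT assay (a higher number here means that more compound is tolerated, a lower number that less compound is tolerated), compound 1 gives 150000 nM.
Compound 2, `OC[C@@H]1[C@@H](O)[C@H](O)[C@@H](O)CN1CCCc1ccccc1OC1CCCCC1` — in this assay compound 2 gives 420000 nM.

Of the two numbers, compound 1 has the lower one; compound 2 sits higher, and the gap between them lies beyond the usual scatter, so compound 1 is the less tolerated of the pair. The two compounds differ in several places at once, so nothing can be read from that gap about any single change.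

Compound 3, `CCC1CCCCC1OCCCCCCN1C[C@H](O)[C@@H](O)[C@H](O)[C@H]1CO`, has not yet been measured in this assay. It is reached from compound 1 by a small change: hydrogen in place of methyl on a saturated chain carbon, two bonds along the chain from a saturated ring carbon. Within the data shown here, no measured pair shows what the loss of a single methyl does here, so the expectation rests only on the size of the change. Because compound 1 gives 150000 nM, compound 3 is expected to land close to it, with a step of a 1.2-fold higher number from compound 1 to compound 3 (0.08 log units; within the scatter) that most likely stays within the scatter, if anything slightly toward a higher number. The estimate for compound 3 is 180000 nM, with a range from 90000 nM to 360000 nM.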

Compound 3, half-maximal cytotoxic concentration: 450000 nM
The estimate for compound 3 lay 2.5-fold (0.40 log units) below the measured number; measured number above the stated range.
By their numbers in this assay, from the lowest: compound 1; then compounds 2 and 3 (each within the scatter of the next).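

The earlier compounds shown here offered no comparison in a single place, and compound 1 and compound 3 now supply the first. In this assay, hydrogen in place of methyl on a saturated chain carbon, two bonds along the chain from a saturated ring carbon, which can also be read as propyl to ethyl, gives a 3.0-fold higher number from compound 1 to compound 3 (0.48 log units; beyond the scatter) in this one pair. The position is therefore not indifferent to this change: the loss of a single carbon, with no hydrogen-bond donor, acceptor or net charge entering or leaving, moves the number beyond the scatter toward more compound tolerated, though no measurement available here bears on why.

On these data alone, a single step cannot show whether the number keeps rising as the chain shortens or falls as it lengthens, so the outcome with a methyl or a butyl chain at this position remains open, as does the outcome with an amine or a carboxylic acid there. As far as these compounds go, it also remains open whether the same change would give a similar step on any compound other than compound 1.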